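The source may hold more compounds than are shown below. What is called first, only, known or untested is meant among the compounds shown, and "the series" means these compounds.

Going by the values given here, in an ADME assay on HFF cells (Homo sapiens) for cytotoxicity, read by neutral red uptake (a higher number here means that more compound is tolerated, a lower number that less compound is tolerated), compound 1 (`Nc1ncnc2c1ncn2/C=C1/C[C@H]1[C@H](O)CO`) gives 206000 nM as the only exact number so far. Compound 2 (`Nc1nc2c(ncn2/C=C2\C[C@@H]2[C@@H](O)CO)c(=O)[nH]1`) gives > 300000 nM as a limit and not a number. Compound 3 (`Nc1nc2c(ncn2/C=C2/C[C@@H]2[C@@H](O)CO)c(=O)[nH]1`) gives > 300000 nM as a limit too.

Compound 4 (`Nc1ncnc2c1ncn2/C=C1/C[C@@H]1[C@H](O)CO`) has not been measured. Its difference from compound 1 is this: the two compounds have the same atoms and bonds and differ only in configuration as drawn: 1 of 3 stereo elements differ; a stereocentre at a saturated ring carbon is drawn R in compound 1 and S in compound 4 ( a stereocentre at a saturated ring carbon is drawn R in compound 1 and S in compound 4 ).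

The nearest parallel is the pair of compound 2 and compound 3, given the fact that compounds 2 and 3 differ only in the configuration as drawn ( though there a double bond changes, not a ring carbon, and the core differs from that of compound 1 ). That comparison yields a step that the two limits leave unreadable from compound 2 to compound 3 because of the limit of > 300000 nM in this assay, at which 2 of the 3 values shown sit ( so it offers no size to carry over ).

With the value of compound 1 at 206000 nM as the only anchor, no step beyond the scatter is expected in this assay and neither direction is favoured. The expected change is a 1.0-fold higher number from compound 1 to compound 4 (0.01 log units; within the scatter) ( an estimate only ). For compound 4 the estimated value is 210000 nM with an expected range from 110000 nM to 300000 nM ( still to be tested ).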

Compound 4, half-maximal cytotoxic concentration: > 300000 nM
Compound 4: no number, only a limit; the forecaster's own chance of this, stated with the estimate: 30%; at least 1.4-fold (0.15 log units) between middle value and limit.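

In this assay, redrawing one stereocentre at a saturated ring carbon, with atoms and bonds unchanged, gives an at least 1.4-fold higher number from compound 1 to compound 4 (0.16 log units; that floor lies within the scatter). Going by these compounds alone, this is the first readable step for a change of configuration alone, since the step between compound 2 and compound 3 cannot be read. Compound 4 gives > 300000 nM, which is a limit and not a number.

From the compounds shown here alone, what stays open is how large the real gap is, since the step has only a floor and that floor alone does not show a true difference between the two compounds. Also open, going by these compounds, is whether this ring carbon matters on the core of compound 2, or with a carboxylic acid in place of a hydroxyl group.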